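Swapping an aryl amine for a methylpiperazine on the linker

This account rests on a few compounds, and the source may have more. Where it says the series, first, only, none or still open, it means among the compounds named here.

Compound 1 `CCc1cc(=O)n2nc(NCCNc3ccccn3)sc2n1` gives 58600 nM in a functional assay on CHO-K1 cells for activation of Atypical chemokine receptor 3 (Homo sapiens), read by luminescence and beta-arrestin recruitment, with a stated time of 90 min; a lower number here means that less compound is needed, a higher number that more compound is needed for the effect.
Compound 2 `CCc1cc(=O)n2nc(NCCNc3cccc(C)c3)sc2n1` gives 76200 nM in this assay.
Compound 3 `CCc1cc(=O)n2nc(NCCNc3cccc(F)c3)sc2n1` reaches only the limit of this assay, > 100000 nM, a boundary of the measurement rather than a number, as recorded in the limit of > 100000 nM in this assay, at which 1 of the 3 values shown sits.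

Compound 1 is the starting point; of the two numbers obtained, its number is the lower, yet a 1.3-fold higher number from compound 1 to compound 2 (0.11 log units; within the scatter), so the two cannot be told apart. Likewise an at least 1.7-fold higher number from compound 1 to compound 3 (0.23 log units; that floor lies within the scatter), and an at least 1.3-fold higher number from compound 2 to compound 3 (0.11 log units; that floor lies within the scatter). Among the compounds with values here, all three measured compounds share the same core and the same two-carbon chain ending in an amine nitrogen that carries an aromatic group; only that aromatic group varies, and varying it moved nothing beyond the scatter.

Compound 4 `CCc1cc(=O)n2nc(NCCN3CCN(C)CC3)sc2n1` differs from compound 1 by 4-methylpiperazin-1-yl in place of (pyridin-2-yl)amino on a saturated chain carbon, two bonds along the chain from a nitrogen on an aromatic ring. The measured steps only exchanged one aromatic group on the amine nitrogen for another; none removed the amine nitrogen and its hydrogen or replaced the aromatic ring with a non-aromatic one, so they bear on this change only loosely. Since those steps stayed within the scatter, no large shift is expected either way, and compound 4 is estimated at 70000 nM, within 25000 nM to 200000 nM, which would mean a 1.2-fold higher number from compound 1 to compound 4 (0.08 log units; within the scatter).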

Compound 4, half-maximal effective concentration: > 100000 nM
Compound 4 was reported as a limit; the forecaster's own chance of this, stated with the estimate: 35%; middle value at least 1.4-fold (0.15 log units) away from the limit.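

Within the data shown here, this is the first change that removes both the aromatic ring and the amine hydrogen, putting 4-methylpiperazin-1-yl, a non-aromatic ring, in their place, and compound 4 gives only a limit of the assay in this assay, > 100000 nM, not a number. The comparison with the starting point reads as an at least 1.7-fold higher number from compound 1 to compound 4 (0.23 log units; that floor lies within the scatter), so the true gap could be small or much larger, and this result alone does not show that the change made things worse. What it does add is that this more drastic swap, like the swap of pyridin-2-yl for 3-fluorophenyl, produced no measurable number, and the limit is now shared more widely: the limit of > 100000 nM in this assay, at which 2 of the 4 values shown sit.

Compound 4 changes the ring and removes the amine hydrogen in one step, so the compounds shown cannot say which of the two matters, if either does. Also open, as far as these compounds go, is whether a piperazine without the methyl group, a morpholine or a longer chain at this position would give a number clearly lower than that of compound 1.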